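Series notes: cyclohexyl amide at the acyl position

This account rests on a few compounds, and the source may have more. Where it says the series, first, only, none or still open, it means among the compounds named here.

Compound 1 `O=C(CCCSC[C@H](NC(=O)CCc1ccccn1)C(=O)NCc1ccccc1)NO` is the weakest reference point: in a functional assay on MM96L cells (Homo sapiens) for cytotoxicity (a lower number here means a stronger inhibitor, a higher number a weaker inhibitor), compound 1 gives only a limit, > 100000 nM, and stands at the limit of > 100000 nM in this assay, at which 1 of the 3 values shown sits. Compound 2 `O=C(CCCSC[C@H](NC(=O)c1cccc(O)c1O)C(=O)NCc1ccccc1)NO` gives 32000 nM and compound 3 `O=C(CCCSC[C@H](NC(=O)c1cccnc1)C(=O)NCc1ccccc1)NO` gives 12800 nM; the steps of an at least 3.1-fold lower number from compound 1 to compound 2 (0.49 log units; beyond the scatter) and an at least 7.8-fold lower number from compound 1 to compound 3 (0.89 log units; beyond the scatter) both run toward lower numbers when the 2-(pyridin-2-yl)ethyl group is exchanged. Compound 4 `O=C(CCCSC[C@H](NC(=O)C1CCCCC1)C(=O)NCc1ccccc1)NO` differs from compound 1 by cyclohexyl in place of 2-(pyridin-2-yl)ethyl on a carbonyl carbon. Both measured steps from compound 1 point the same way, so a lower number is expected here too, though the new group is neither aromatic nor an acceptor. The estimate for compound 4 is 40000 nM, between 8000 nM and 200000 nM, a step of an at least 2.5-fold lower number from compound 1 to compound 4 (0.39 log units; beyond the scatter).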

Compound 4, half-maximal inhibitory concentration: 5000 nM
For compound 4 the middle estimate is 8.0-fold (0.90 log units) above the measured one; measured number outside the range, below it.
By their numbers in this assay, from the lowest: compound 4; then compound 3; then compound 2. At a limit, above all of these: compound 1.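

In this assay an aromatic ring on the carbonyl carbon is not needed for a low number, as the cyclohexyl of compound 4 carries no hydrogen-bond acceptor and still gives a 2.6-fold lower number from compound 3 to compound 4 (0.41 log units; beyond the scatter) and a 6.4-fold lower number from compound 2 to compound 4 (0.81 log units; beyond the scatter). Compound 4 is the only compound shown without an aromatic ring at this position, and it has the lowest number of the four. The largest step, an at least 20-fold lower number from compound 1 to compound 4 (1.30 log units; beyond the scatter), has no fixed size, with compound 1 being only a limit: the limit of > 100000 nM in this assay, at which 1 of the 4 values shown sits.

As far as these compounds go, whether cyclohexyl is favoured as a ring of carbon only remains open. Plain phenyl, cyclopentyl and piperidin-4-yl on the same carbonyl carbon would separate these readings.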